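This account rests on a few compounds, and the source may have more. Where it says the series, first, only, none or still open, it means among the compounds named here.

Measured so far:
compound 1 `C[C@H]1[C@H](NCc2ccc(Br)s2)C[C@H]2C[C@@H]1C2(C)C` in an ADME assay on MDCK cells (Canis lupus familiaris) for cytotoxicity, read by microscopy, with a stated time of 48 h; a lower number here means that less compound is tolerated, a higher number that more compound is tolerated: compound 1 gives 43000 nM
compound 2 `Cc1csc(CN[C@@H]2C[C@H]3C[C@@H]([C@H]2C)C3(C)C)c1`: compound 2 gives 12500 nM

Among the measured compounds shown here, compound 2 holds the lowest of the two numbers, and the only step so far, a 3.4-fold lower number from compound 1 to compound 2 (0.54 log units; beyond the scatter), is the one that bears on the new case. Compound 3 `C[C@H]1[C@H](NCc2ccco2)C[C@H]2C[C@@H]1C2(C)C` differs from compound 2 in one place: furan-2-yl in place of 4-methylthiophen-2-yl on a saturated chain carbon bound to an amine nitrogen. For the measured compounds named here, no measured step exchanges one five-membered ring for another of this kind, so the direction is open; a step like a 1.6-fold higher number from compound 2 to compound 3 (0.20 log units; within the scatter) is expected, toward a somewhat higher number. Compound 3 is therefore estimated at 20000 nM, between 6000 nM and 60000 nM.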

Compound 3, minimum cytotoxic concentration: 50000 nM
For compound 3 the middle estimate is 2.5-fold (0.40 log units) below the measured one; measured number inside the range.
By their numbers in this assay, from the lowest: compound 2; then compounds 1 and 3 (each within the scatter of the next).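

In this assay the furan-2-yl group gives a 4.0-fold higher number from compound 2 to compound 3 (0.60 log units; beyond the scatter) at this place, on a saturated chain carbon bound to an amine nitrogen. Set against the 5-bromothiophen-2-yl group, the same furan-2-yl shows a 1.2-fold higher number from compound 1 to compound 3 (0.07 log units; within the scatter) and so no difference, which leaves compound 2, with its 4-methylthiophen-2-yl, alone apart from the other two. Nothing given here accounts for these steps.

Open, on these data alone, is how phenyl or unsubstituted thiophen-2-yl would stand at this place, and so whether the methyl group or the thiophene ring goes with the lower number of compound 2.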